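The source may report more compounds than this note shows. Statements on the series, on what has been measured and on what is new or still open speak of the compounds shown alone.

Of the compounds shown here, three built on a shared core have been measured in a functional assay on MCF7 cells (Homo sapiens) for inhibition, read by sulforhodamine B assay, with a stated time of 24 h; a lower number here means a stronger inhibitor of growth, a higher number a weaker inhibitor of growth. Compound 1 `CC1=C(C(=O)Nc2ccccc2)C(c2cn(-c3ccccc3)nc2-c2ccccc2)NC(=S)N1` gives 88200 nM in this assay. Within the data shown here, compound 2 `COc1ccc(NC(=O)C2=C(C)NC(=S)NC2c2cn(-c3ccccc3)nc2-c2ccccc2)cc1` gives 77300 nM in this assay; the single step of a 1.1-fold lower number from compound 1 to compound 2 (0.06 log units; within the scatter) goes with a methoxy in place of hydrogen on an aromatic carbon. Compound 3 `CCOC(=O)C1=C(C)NC(=O)NC1c1cn(-c2ccccc2)nc1-c1ccc(Cl)cc1` gives 68800 nM in this assay. Among the measured compounds shown here, compound 3 differs from compounds 1 and 2 in more than one place, so no single step joins them; its number stands within the scatter of compound 2 and of compound 1 alike, and the three cannot be told apart on these numbers.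

Compound 4 `CC1=C(C(=O)Nc2ccc(Cl)cc2)C(c2cn(-c3ccccc3)nc2-c2ccc(Cl)cc2)NC(=O)N1` has not yet been measured. It differs from compound 3 by (4-chlorophenyl)amino in place of ethoxy on a carbonyl carbon. For the measured compounds named here, no measured step bears directly on this change: the only single step in hand, that between compound 1 and compound 2, concerns a methoxy elsewhere and stayed within the scatter. Compounds 1 and 2, which resemble compound 4 at this carbonyl carbon more than compound 3 does, give numbers within the scatter of compound 3, which speaks against any large step. Compound 4 is therefore expected to sit close to compound 3, with a 1.0-fold higher number from compound 3 to compound 4 (0.01 log units; within the scatter) expected to stay within the scatter. The estimate for compound 4 in this assay is 70000 nM, with a range from 30000 nM to 160000 nM.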

Compound 4, concentration for 50% growth inhibition: 56900 nM
Beside the measured number, compound 4's estimate is 1.2-fold (0.09 log units) above it; the measured number falls inside the stated range.
By their numbers in this assay, from the lowest: compounds 4, 3, 2 and 1 (each within the scatter of the next).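

On the carbonyl carbon whose other neighbour is the double-bonded ring carbon, placing (4-chlorophenyl)amino in place of ethoxy gives a 1.2-fold lower number from compound 3 to compound 4 (0.08 log units; within the scatter) in this assay. Among these compounds, this is the first direct reading at this position, and it shows that an exchange of a small chain without a ring for a larger group with a six-membered aromatic ring and a hydrogen-bond donor leaves two numbers that cannot be told apart in this pair; the earlier step concerned a methoxy on an aromatic carbon and could say nothing about this carbonyl carbon. Nothing measured here offers an explanation for this result.

As far as these compounds go, it remains open whether a carboxylic acid, a simple amine or a longer chain such as butoxy on this carbonyl carbon would give a number beyond the scatter of compound 3. The compounds shown also offer no pair that isolates the chlorine of the entering ring, or the sulfur of compound 1 and compound 2 against the oxygen at that place in compound 3 and compound 4.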